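The compounds below may be only part of what the source reports. "The series", "measured", "known", "first", "only" and "open" are said of these compounds alone.

In an ADME assay on the whole organism (Mus musculus, strain CD-1) for pharmacokinetics, read by LC-MS, with a stated time of 7 h, at a dose of 10 mg/kg by the intraperitoneal route (on this read-out higher numbers stand for higher exposure at the dose given and lower numbers for lower exposure), compound 2 (`CC(Sc1nc2c(cnn2C)c(=O)n1-c1ccccc1)c1ccccn1`) gives 2870 ng.h/mL, the middle of the three measured numbers. Compound 3 (`CC(Sc1nc2nn(C3COC3)cc2c(=O)n1-c1ccccc1)c1ccccc1`) stands higher at 7890 ng.h/mL, and compound 1 (`C[C@@H](Sc1nc2c(cnn2C)c(=O)n1-c1ccccc1)c1ccccc1`) stands lowest at 254 ng.h/mL. The next structure is compound 4 (`CC(Sc1nc2c(cnn2C)c(=O)n1-c1ccccc1)c1ccccc1`), reached from compound 2 by the change phenyl in place of pyridin-2-yl on a saturated chain carbon bound to a saturated chain carbon and a sulfur.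

Within the data shown here, one measured step bears on it: an 11-fold higher number from compound 1 to compound 2 (1.05 log units; beyond the scatter), large and beyond the scatter, for the same exchange of groups run the other way. Compound 1 differs from compound 4 only in having a defined configuration at that saturated chain carbon, while none is drawn for compound 4 or compound 2. Compound 3 differs from compound 2 in more than one place and offers no direct guide.

A large fall in this assay is therefore expected, anchored on compound 1 at 254 ng.h/mL. The opposite configuration has no measurement of its own, so the estimate leaves room upward. The expected step runs a 6.4-fold lower number from compound 2 to compound 4 (0.80 log units; beyond the scatter). Compound 4 is estimated at 450 ng.h/mL, with an expected range from 160 ng.h/mL to 1500 ng.h/mL.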

Compound 4, area under the concentration-time curve: 1780 ng.h/mL
Beside the measured number, compound 4's estimate is 4.0-fold (0.60 log units) below it; the measured number lies above the stated range.
By their numbers in this assay, from the lowest: compound 1; then compounds 4 and 2 (each within the scatter of the next); then compound 3.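

In this assay, the exchange of pyridin-2-yl for phenyl on a saturated chain carbon bound to a saturated chain carbon and a sulfur, with no configuration drawn on either side, gives a 1.6-fold lower number from compound 2 to compound 4 (0.21 log units; within the scatter), so with the configuration left undrawn this change does not separate the two compounds. The gap beyond the scatter now appears between two compounds with the same atoms and bonds, as a 7.0-fold higher number from compound 1 to compound 4 (0.85 log units; beyond the scatter). Among these compounds, the earlier 11-fold higher number from compound 1 to compound 2 (1.05 log units; beyond the scatter) can therefore no longer be read as the effect of the ring exchange alone, because that step also carries a difference in drawn configuration, and the same difference is the only one in the step to compound 4: the fact that one of compounds 1 and 4 is drawn with a defined configuration and the other without, at the place where they differ.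

Still open, as far as these compounds go, is how the opposite configuration at this saturated chain carbon reads, and whether a defined configuration would give the same gap with pyridin-2-yl in place of phenyl. Also open, from the compounds shown here alone, is how a different group on this carbon, such as cyclohexyl or pyridin-3-yl, would read in this assay.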